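The source may report more compounds than this note shows. Statements on the series, on what has been measured and on what is new or still open speak of the compounds shown alone.

Going by the values given here, compound 2 `NS(=O)(=O)CC(=O)NCCSc1nonc1/C(=N/O)Nc1ccc(F)c(Br)c1` gives 12 nM in an assay for inhibition of Indoleamine 2,3-dioxygenase 1 (Homo sapiens), read by fluorescence, with a stated time of 24 h (on this read-out lower numbers stand for stronger inhibition and higher numbers for weaker inhibition), the higher of the two numbers measured so far; compound 1 `NS(=O)(=O)CC(=O)NCCSc1nonc1/C(=N/O)Nc1cccc(Cl)c1` gives 10 nM in this assay, and the two sit within the usual scatter of each other, since a 1.2-fold higher number from compound 1 to compound 2 (0.08 log units; within the scatter).

Compound 3 `N#Cc1cccc(N/C(=N\O)c2nonc2SCCNC(=O)CS(N)(=O)=O)c1` has not been measured yet. It differs from compound 2 in one place: 3-cyanophenyl in place of 3-bromo-4-fluorophenyl on an amine nitrogen. Among the compounds with values here, only one measured step bears on this change, the one from a 3-chlorophenyl to a 3-bromo-4-fluorophenyl on the same amine nitrogen, and that step was flat: a 1.2-fold higher number from compound 1 to compound 2 (0.08 log units; within the scatter). It shows that swapping one halogen pattern on this phenyl ring for another left the number where it was. Within the data shown here, the step to compound 3 is of a different kind, since a nitrile replaces the two halogens, and no measured pair shows what a nitrile does here. With nothing pointing either way, the step expected in this assay is small, a 1.2-fold higher number from compound 2 to compound 3 (0.07 log units; within the scatter), in no particular direction beyond the scatter. Compound 3 is therefore estimated at 14 nM, with a range from 5 nM to 45 nM to allow for the untested nitrile.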

Compound 3, half-maximal inhibitory concentration: 44 nM
The estimate for compound 3 lay 3.1-fold (0.50 log units) below the measured number; the measured number falls inside the stated range.
By their numbers in this assay, from the lowest: compounds 1 and 2 (each within the scatter of the next); then compound 3.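

In this assay, the phenyl ring on this amine nitrogen turns out not to be indifferent to what it carries: the earlier swap between halogen patterns left the number within the scatter, whereas the change to 3-cyanophenyl gives a 3.7-fold higher number from compound 2 to compound 3 (0.56 log units; beyond the scatter). The most direct comparison, in which cyano simply takes the place of chloro on an aromatic carbon, gives a 4.4-fold higher number from compound 1 to compound 3 (0.64 log units; beyond the scatter), so both steps are modest but lie beyond the scatter, and among these three compounds the two carrying halogens give the lower numbers while the nitrile compound gives the highest. No measurement available here explains why the number rises with the nitrile.

The compounds shown carry only chloro, bromo with fluoro, or cyano on this ring, so it stays open whether the rise is specific to the nitrile or would follow from replacing the halogens with other groups. A phenyl ring bearing a methyl or a methoxy group, or no added group at all, on the same amine nitrogen would help to separate these two readings.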